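Turning One Ring Carbon the Other Way

The source may report more compounds than this note shows. Statements on the series, on what has been measured and on what is new or still open speak of the compounds shown alone.

In an assay on isolated protein for inhibition of protein kinase C delta type (Homo sapiens), read by TR-FRET, with a stated time of 2 h (on this read-out lower numbers stand for stronger inhibition and higher numbers for weaker inhibition), compound 1 `N#Cc1cnc(NCc2cnccc2C(F)(F)F)cc1NC[C@H]1CC[C@H](O)CC1` gives 2000 nM. Compound 2 `CC1(C)C[C@H](Nc2cc(NCc3cnccc3C(F)(F)F)ncc2C#N)CC[C@@H]1O` carries a 4-hydroxy-3,3-dimethylcyclohexyl group in place of the (4-hydroxycyclohexyl)methyl group on a nitrogen on an aromatic ring, and in this assay compound 2 gives 500 nM. Among the measured compounds shown here, that swap produced a 4.0-fold lower number from compound 1 to compound 2 (0.60 log units; beyond the scatter), so compound 2 has the lowest number of the two measured so far.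

Compound 3 `CC1(C)C[C@H](Nc2cc(NCc3cnccc3C(F)(F)F)ncc2C#N)CC[C@H]1O` differs from compound 2 as follows: the two compounds have the same atoms and bonds and differ only in configuration as drawn: 1 of 2 stereo elements differ; a stereocentre at a saturated ring carbon is drawn S in compound 2 and R in compound 3. Nothing else moves. For the measured compounds named here, no measured step changes only a configuration, so none of the steps seen so far bears directly on this one; the step measured so far exchanged whole groups. Without any guide from the data, the expected outcome is a mild loss, a 2.0-fold higher number from compound 2 to compound 3 (0.30 log units; within the scatter), with wide uncertainty in either direction. In this assay compound 3 is therefore estimated at 1000 nM, within a range from 250 nM to 4000 nM.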

Compound 3, half-maximal inhibitory concentration: 2200 nM
Compound 3: the middle estimate sits 2.2-fold (0.34 log units) below what was measured; measured number inside the range.
By their numbers in this assay, from the lowest: compound 2; then compounds 1 and 3 (each within the scatter of the next).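

Here no atom changes, yet a 4.4-fold higher number from compound 2 to compound 3 (0.64 log units; beyond the scatter) in this assay, so the arrangement at one saturated ring carbon matters, not only which group is attached. The loss can be traced to that single ring carbon, because nothing else separates the pair: the fact that compounds 2 and 3 differ only in the configuration as drawn. The earlier gain therefore does not belong to the 4-hydroxy-3,3-dimethylcyclohexyl group as such: with this ring carbon drawn R, the same swap gives a 1.1-fold higher number from compound 1 to compound 3 (0.04 log units; within the scatter).

The compounds shown leave open what the second stereocentre contributes, since it stays the same in this pair. They also leave open whether the preference for the S arrangement would hold with an amine or a methoxy group in place of the hydroxy group.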